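The source may hold more compounds than are shown below. What is called first, only, known or untested is meant among the compounds shown, and "the series" means these compounds.

Compound 1 `Cc1nc(S(C)(=O)=O)ccc1Oc1ncnc(OC2CCN(C(=O)OC(C)C)CC2)c1F` is the reference point of this small set. In a functional assay on isolated protein for inhibition of Glucose-dependent insulinotropic receptor (Homo sapiens), read by HTRF and cAMP accumulation (on this read-out lower numbers stand for an effect already at smaller amounts and higher numbers for an effect only at larger amounts of compound), compound 1 gives 21 nM, the second highest of the three numbers measured. Compound 2 `Cc1nc(S(C)(=O)=O)ccc1Oc1ncnc(OC2CCN(C(=O)OC(C)(C)C(F)(F)F)CC2)c1F` gives 6.53 nM in this assay, and compound 3 `Cc1nc(S(C)(=O)=O)ccc1Oc1ncnc(OC2CCN(C(=O)OC(C)F)CC2)c1F` gives 65.5 nM.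

Compound 4 `Cc1nc(S(C)(=O)=O)ccc1Oc1ncnc(OC2CCN(C(=O)O[C@H](C)C(F)(F)F)CC2)c1F` differs from compound 1 in one place: 1-(trifluoromethyl)ethyl in place of isopropyl on an oxygen next to a carbonyl group. Among the compounds with values here, two measured steps bear on this change. The step of a 3.2-fold lower number from compound 1 to compound 2 (0.51 log units; beyond the scatter) shows what a trifluoromethyl added on the carbon bound to the oxygen next to the carbonyl did when the two methyls were kept; the step of a 3.1-fold higher number from compound 1 to compound 3 (0.49 log units; beyond the scatter) shows that removing a methyl from that carbon in favour of fluoro moved the number the other way. Compound 4 keeps one methyl and carries a trifluoromethyl in the other position, so it sits between compound 2 and compound 3, and the contrast a 10-fold higher number from compound 2 to compound 3 (1.00 log units; beyond the scatter) brackets the plausible outcome.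

Compound 4 is therefore expected to give a somewhat lower number than compound 1, with an expected step of a 1.9-fold lower number from compound 1 to compound 4 (0.28 log units; within the scatter). The estimate for compound 4 in this assay is 11 nM, with a range from 4 nM to 28 nM.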

Compound 4, half-maximal effective concentration: 9.2 nM
Beside the measured number, compound 4's estimate is 1.2-fold (0.08 log units) above it; the measured number falls inside the stated range.
By their numbers in this assay, from the lowest: compounds 2 and 4 (each within the scatter of the next); then compound 1; then compound 3.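

In this assay, a trifluoromethyl in place of just one methyl of the isopropyl group already gives a step beyond the scatter (a 2.3-fold lower number from compound 1 to compound 4 (0.36 log units; beyond the scatter)), whereas the further methyl carried by compound 2 makes no readable difference (a 1.4-fold higher number from compound 2 to compound 4 (0.15 log units; within the scatter)); on this oxygen next to a carbonyl group, the gain seen with compound 2 therefore does not depend on that extra methyl. Within the data shown here, with the methyl held constant, trifluoromethyl in place of the fluoro of the 1-fluoroethyl group gives the largest of the new steps (a 7.1-fold lower number from compound 3 to compound 4 (0.85 log units; beyond the scatter)), so this pair isolates what the earlier comparisons could only show together with a change in the number of methyls. The data shown give no explanation for these steps.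

On these data alone, compound 4 carries one defined stereocentre, and what the opposite configuration at that carbon would give remains open. Also open, as far as these compounds go, is whether a 2,2,2-trifluoroethyl group, with no methyl left on the carbon bound to the oxygen, or a larger chain such as a 1-(pentafluoroethyl)ethyl group would keep the number in this range.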